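Swapping the aryl group on a shared core

This account rests on a few compounds, and the source may have more. Where it says the series, first, only, none or still open, it means among the compounds named here.

Measured compounds in a functional assay on HeLa cells (Homo sapiens) for inhibition, read by sulforhodamine B assay; on this read-out lower numbers stand for stronger inhibition and higher numbers for weaker inhibition:
Compound 1 `CCc1ccc(NC2=CC(=O)c3c(nc4n3[C@H]3OC[C@@H](O)[C@H]3OC4)C2=O)cc1`: 6510 nM
Compound 2 `O=C1C=C(NC2CCCC2)C(=O)c2c1nc1n2[C@H]2OC[C@@H](O)[C@H]2OC1`: > 16000 nM, a limit of the assay
Compound 3 `O=C1C=C(Nc2ccc(C(F)(F)F)cc2)C(=O)c2c1nc1n2[C@H]2OC[C@@H](O)[C@H]2OC1`: > 8000 nM, a limit of the assay

For the measured compounds named here, compound 1 stands as the only compound with a number in this assay; the two others give only limits. For compound 2 the value is a limit, (the limit of > 16000 nM in this assay, at which 1 of the 3 values shown sits). For compound 3 the value is also a limit, (the limit of > 8000 nM in this assay, at which 1 of the 3 values shown sits). Going by the values given here, the only step between measured compounds that differ in one place, a step that the two limits leave unreadable from compound 2 to compound 3, is therefore unreadable in size.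

Compound 4 `O=C1C(Nc2cccc(Cl)c2)=CC(=O)c2c1nc1n2[C@H]2OC[C@@H](O)[C@H]2OC1` is not yet measured. It differs from compound 1 as follows: 3-chlorophenyl in place of 4-ethylphenyl on an amine nitrogen. Among the compounds with values here, no measured step bears directly on this change, since both compounds 2 and 3 sit at limits and neither carries a chlorophenyl group. What the data do show is that compound 3, which also carries an aryl group on the amine nitrogen, reaches only a limit, while compound 1 gives a number. An aryl-to-aryl change on this nitrogen can thus weaken inhibition well beyond the scatter, and a loss is the more likely direction. Compound 4 is expected to show a step of a 1.4-fold higher number from compound 1 to compound 4 (0.14 log units; within the scatter), with a value estimated at 9000 nM and a range from 3000 nM to 25000 nM.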

Compound 4, half-maximal inhibitory concentration: 7970 nM
Compound 4: middle estimate off by 1.1-fold (0.05 log units), on the high side; the range from low to high includes it.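

In this assay, for the compounds shown here, putting 3-chlorophenyl in place of 4-ethylphenyl on the amine nitrogen gives a 1.2-fold higher number from compound 1 to compound 4 (0.09 log units; within the scatter), the first step of readable size at this position, and it shows that one aryl group can replace another here without moving the number beyond the scatter. Compound 3, which carries 4-(trifluoromethyl)phenyl on the same nitrogen, remains a limit of the assay at > 8000 nM, so it cannot be placed on the same scale and stands as a possible exception to that tolerance rather than a measured one. Nothing measured among these compounds accounts for why the 4-ethylphenyl and 3-chlorophenyl groups behave alike in this read-out.

The step from compound 2 to compound 3 still cannot be read, as both of its ends are limits, so the cyclopentyl and aryl groups on this nitrogen remain without a sized comparison. Also open, on these data alone, is how the number would respond to 4-chlorophenyl on this nitrogen, to a longer chain in place of the ethyl group, or to a carboxylic acid or an amine on the phenyl ring.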